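A few compounds are considered here, and "the series" means these few. Any claim that something is new, unique, unknown or untested is made for them only; others in the source may bear on it.

The compounds measured so far:

Compound 1, `O=C1C(=O)N(CN2CCN(c3ccnc4cc(Cl)ccc34)CC2)c2cccc(Cl)c21`, in an ADME assay on MCF-10A cells (Homo sapiens) for cytotoxicity, read by sulforhodamine B assay, with a stated time of 48 h (a lower number here means a stronger inhibitor of growth, a higher number a weaker inhibitor of growth), gives 25600 nM.
Compound 2, `O=C1C(=O)N(CN2CCN(c3ccnc4cc(Cl)ccc34)CC2)c2cccc(Br)c21`, in this assay gives 65600 nM.
Compound 3, `NC(=S)N/N=C1/C(=O)N(CN2CCN(c3ccnc4cc(Cl)ccc34)CC2)c2cc(Cl)ccc21`, in this assay gives 64600 nM.

Compound 4, `NC(=S)N/N=C1/C(=O)N(CN2CCN(c3ccnc4cc(Cl)ccc34)CC2)c2cc(Br)ccc21`, has not yet been measured in this assay. It differs from compound 3 in one place: bromo in place of chloro on an aromatic carbon. The same kind of change links the two measured compounds 1 and 2, where it reads (bromo in place of chloro on an aromatic carbon). The surroundings are not identical, though: in compound 1 the exchanged atom sits ortho to a fused ring and meta to a fused ring, while in compound 3 it sits meta to a fused ring and para to a fused ring. The difference between the core of compound 1 and the core of compound 3 is not broken down here.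

In this assay that exchange gave a 2.6-fold higher number from compound 1 to compound 2 (0.41 log units; beyond the scatter), a modest weakening of growth inhibition. Compound 3 and compound 2 give numbers within the scatter of one another, so there is no order to draw between them. Among the compounds with values here, with only a single precedent, the expectation for compound 4 rests on the step from compound 1 to compound 2: a similar, modest rise in the number is expected, a 1.9-fold higher number from compound 3 to compound 4 (0.27 log units; within the scatter). Given how high the value of compound 3 already stands, there is a fair chance that the result for compound 4 comes back only as a limit. The estimate for compound 4 is 120000 nM, expected to lie between 50000 nM and 300000 nM.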

Compound 4, concentration for 50% growth inhibition: 22100 nM
Estimate against measurement, compound 4: 5.4-fold (0.73 log units) above, and the stated range ends above it.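

In this assay, putting bromo in place of chloro on an aromatic carbon gave a 2.9-fold lower number from compound 3 to compound 4 (0.47 log units; beyond the scatter), so on this core the exchange strengthened growth inhibition, whereas on the core of compound 1 the same exchange weakened it. Set side by side, the two steps run in opposite directions, and the gap between them is larger than the scatter can account for: the same change on two cores in this assay, a 2.6-fold higher number (0.41 log units; beyond the scatter) from compound 1 to compound 2 and a 2.9-fold lower number (0.47 log units; beyond the scatter) from compound 3 to compound 4, 7.5-fold (0.87 log units) apart, beyond the scatter of two such steps

Within the data shown here, this shows that, in this series, the effect of the exchange cannot simply be carried from one core to another, not even in its direction; it does not show which difference between the two cores is responsible, as the place of the halogen and the rest of the core change together, and the comparison rests on only one pair for each core.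

Still open, from the compounds shown here alone, is what the same exchange does when the halogen sits at the place it holds in compound 3 while the rest of the core matches compound 1, a comparison that would separate these two differences. Also open, going by these compounds, is how a fluoro, methyl or methoxy group at that place on the core of compound 3 would compare with chloro and bromo.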